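This account rests on a few compounds, and the source may have more. Where it says the series, first, only, none or still open, it means among the compounds named here.

In a functional assay on HeLa cells (Homo sapiens) for inhibition, read by MTT assay, with a stated time of 72 h (on this read-out higher numbers stand for weaker inhibition and lower numbers for stronger inhibition), compound 2, `O=C(O)/C=C/C(=O)c1ccccc1`, gives 30600 nM, the highest of the two numbers recorded so far. Its nearest neighbour is compound 1, `CC(C)(C)c1ccc(C(=O)/C=C/C(=O)O)cc1`, which in this assay gives 5100 nM. Within the data shown here, the only measured step that joins them, a 6.0-fold higher number from compound 1 to compound 2 (0.78 log units; beyond the scatter), came with a hydrogen in place of tert-butyl on an aromatic carbon, so the compound carrying the larger group returned the lower number.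

Compound 3, `CC(C)c1ccc(C(=O)/C=C/C(=O)O)cc1`, is the next compound for this assay. It differs from compound 2 by isopropyl in place of hydrogen on an aromatic carbon, the entering group sitting on an aromatic carbon of a six-membered aromatic ring of carbon only, para to a group of 7 heavy atoms. Among the measured compounds shown here, the one step that bears on this change is a 6.0-fold higher number from compound 1 to compound 2 (0.78 log units; beyond the scatter); it ran in the opposite direction, and the group it concerned was tert-butyl rather than isopropyl. A step of moderate size toward a lower number is therefore expected, a 3.4-fold lower number from compound 2 to compound 3 (0.53 log units; beyond the scatter), though not as large as the measured one. For compound 3 the estimate in this assay is 9000 nM, with a range from 4000 nM to 25000 nM.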

Compound 3, half-maximal inhibitory concentration: 4900 nM
Beside the measured number, compound 3's estimate is 1.8-fold (0.26 log units) above it; the measured number falls inside the stated range.
By their numbers in this assay, from the lowest: compounds 3 and 1 (each within the scatter of the next); then compound 2.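

In this assay, isopropyl on an aromatic carbon of the six-membered aromatic ring of carbon only, para to a group of 7 heavy atoms, brings a 6.2-fold lower number from compound 2 to compound 3 (0.80 log units; beyond the scatter) and so shows that a number lower than that of compound 2 does not depend on tert-butyl alone at this place. Replacing a methyl of tert-butyl with hydrogen, on a saturated chain carbon bound to an aromatic carbon and two saturated chain carbons, gives a 1.0-fold lower number from compound 1 to compound 3 (0.02 log units; within the scatter) and leaves these two groups indistinguishable in this read-out. No supporting measurement is available to explain what either group does here.

The compounds shown leave open whether a smaller group such as methyl or ethyl at this place would already give a number like those of compound 1 and compound 3, and whether a longer chain such as n-butyl would do the same. They also leave open how groups containing atoms other than carbon, such as methoxy, chlorine or an amine, would compare with isopropyl at this place.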